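A few compounds are considered here, and "the series" means these few. Any claim that something is new, unique, unknown or untested is made for them only; others in the source may bear on it.

Compound 1 `OC[C@H]1O[C@@H](n2cnc3c(NCc4ccc(Cl)cc4Cl)ncnc32)[C@H](O)[C@@H]1O` gives 86700 nM
Compound 2 `OC[C@H]1O[C@@H](n2cnc3c(NCc4ccc(F)cc4Cl)ncnc32)[C@H](O)[C@@H]1O` gives 20900 nM

Going by the values given here, in a functional assay on CCRF-CEM cells (Homo sapiens) for antiproliferative activity, with a stated time of 72 h (on this read-out higher numbers stand for weaker inhibition and lower numbers for stronger inhibition), compound 2 gives 20900 nM as the lower of the two numbers so far, which makes it the stronger inhibitor of this pair. Compound 3 `Cc1cccc(CNc2ncnc3c2ncn3[C@@H]2O[C@H](CO)[C@@H](O)[C@H]2O)c1O` differs from it in one place (2-hydroxy-3-methylphenyl in place of 2-chloro-4-fluorophenyl on a saturated chain carbon bound to a nitrogen on an aromatic ring), and neither chlorine nor fluorine remains in the entering group. Among the compounds with values here, only one measured step bears on this change, and it is a modest one: a 4.1-fold lower number from compound 1 to compound 2 (0.62 log units; beyond the scatter) for fluoro in place of chloro on an aromatic carbon. Within the data shown here, no measured compound carries a hydroxy or methyl group on this ring, so the evidence is thin. A modest move toward stronger inhibition is expected, with an estimated 3.0-fold lower number from compound 2 to compound 3 (0.48 log units; beyond the scatter) as the likely step. For compound 3 the estimated value is 7000 nM in a range of 1000 nM to 45000 nM as expected bounds.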

Compound 3, half-maximal inhibitory concentration: 900 nM
Beside the measured number, compound 3's estimate is 7.8-fold (0.89 log units) above it; measured number outside the range, below it.
By their numbers in this assay, from the lowest: compound 3; then compound 2; then compound 1.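

In this assay the aromatic group on a saturated chain carbon bound to a nitrogen on an aromatic ring turns out to matter far more than the swap between two halogens suggested: 2-hydroxy-3-methylphenyl in place of 2-chloro-4-fluorophenyl gives a 23-fold lower number from compound 2 to compound 3 (1.37 log units; beyond the scatter) and, in place of 2,4-dichlorophenyl, gives a 96-fold lower number from compound 1 to compound 3 (1.98 log units; beyond the scatter) as the widest gap in this set. Halogens are therefore not needed on this ring for the strongest inhibition among these compounds, and compound 3 has none. No measurement here accounts for the gain.

Hydroxy and methyl enter together, so the compounds shown do not tell which of them carries the gain, or whether both are needed. As far as these compounds go, whether a methoxy group or an amine could stand in for the hydroxy also remains open.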